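Pyrazole enones: methoxy pattern on the ketone aryl ring

The source may hold more compounds than are shown below. What is called first, only, known or untested is meant among the compounds shown, and "the series" means these compounds.

Numbers so far in a functional assay on HCT-116 cells (Homo sapiens) for inhibition, read by sulforhodamine B assay, with a stated time of 72 h; a higher number here means a weaker inhibitor, a lower number a stronger inhibitor:

compound 1 `O=C(/C=C/c1cn(-c2ccccc2)nc1-c1ccsc1)c1ccccc1`, 5100 nM
compound 2 `COc1cc(C(=O)/C=C/c2cn(-c3ccccc3)nc2-c2ccsc2)cc(OC)c1OC`, 3200 nM
compound 3 `COc1ccc(C(=O)/C=C/c2cn(-c3ccccc3)nc2-c2ccsc2)c(OC)c1OC`, 5800 nM

Compound 3 gives the highest number of the three. Its nearest neighbour is compound 1, a little lower; compound 2 is the furthest away, lower still; yet all three numbers lie within the scatter of one another, so no ordering among them can be read and none of the three may be called the strongest or weakest. No pair among these compounds differs in a single place, so no single-change step has been measured within the series as it stands.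

Compound 4 `COc1ccc(C(=O)/C=C/c2cn(-c3ccccc3)nc2-c2ccsc2)cc1OC` is next to be measured in this assay. It differs from compound 3 in one place: hydrogen in place of methoxy on an aromatic carbon. In plain words, hydrogen in place of methoxy on an aromatic carbon. Within the data shown here, with no measured step of comparable kind, the expectation rests on the narrow spread of the three numbers already in hand. Compound 4 is expected to give 4500 nM, with a range of 2000 nM to 11000 nM. The step of a 1.3-fold lower number from compound 3 to compound 4 (0.11 log units; within the scatter) implied by this estimate is small, toward a lower number, and not beyond the scatter.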

Compound 4, half-maximal inhibitory concentration: 1600 nM
Compound 4: middle estimate off by 2.8-fold (0.45 log units), on the high side; measured number outside the range, below it.
By their numbers in this assay, from the lowest: compounds 4, 2, 1 and 3 (each within the scatter of the next, the first and the last beyond it).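

Notes on the ketone aryl ring: in this assay, hydrogen in place of methoxy on an aromatic carbon ortho to a large group gives a 3.6-fold lower number from compound 3 to compound 4 (0.56 log units; beyond the scatter) and is the first single-place change in the series to clear the scatter, so this one methoxy group on the ring counts against activity in this series. The ring pattern also matters relative to the unsubstituted ring: 3,4-dimethoxyphenyl in place of phenyl on a carbonyl carbon gives a 3.2-fold lower number from compound 1 to compound 4 (0.50 log units; beyond the scatter) and also clears the scatter, so methoxy groups on this ring are not neutral as a class. The effect does not hold for every methoxy group, since the same kind of exchange elsewhere on the ring, with a 2.0-fold lower number from compound 2 to compound 4 (0.30 log units; within the scatter) in the same assay, stays within the scatter and goes against any general rule that removing a methoxy group helps.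

No measurement shown here gives a reason for these steps.

Open, going by these compounds, is whether a hydroxy group, an amine or a fluorine at the carbon ortho to a large group would read like hydrogen or like methoxy. Also open, on these data alone, is whether a longer ether chain such as ethoxy would be tolerated on the ketone aryl ring.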